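Thiazolidinedione saturation: compound 1 to compound 3

A few compounds are considered here, and "the series" means these few. Any claim that something is new, unique, unknown or untested is made for them only; others in the source may bear on it.

Two measured members of the series share the core of compound 1, `CC(C)C(c1ccc(-c2ccc3cccc(F)c3c2)[nH]c1=O)C1SC(=O)NC1=O`, and differ in the acidic heterocycle and the side group on the chain carbon. In an assay on membranes from Chem-1 cells for displacement of a labelled ligand from prostaglandin E2 receptor EP3 subtype (Homo sapiens), read by scintillation counting, with a stated time of 2 h (a lower number here means a stronger inhibitor, a higher number a weaker inhibitor), compound 1 gives 25 nM, and compound 2, `O=C1NC(=O)/C(=C/C(c2ccccc2)c2ccc(-c3ccc4cccc(F)c4c3)[nH]c2=O)O1`, gives 23 nM in this assay; the two numbers lie within the usual scatter of each other, so compound 1 cannot be set apart from compound 2 on these data.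

Compound 3, `CC(C)C(/C=C1\SC(=O)NC1=O)c1ccc(-c2ccc3cccc(F)c3c2)[nH]c1=O`, has not yet been measured. Relative to compound 1 the change is a group of 8 heavy atoms (4 carbon, 1 nitrogen, 2 oxygen, 1 sulfur; one five-membered non-aromatic ring with 2 hetero atoms) in place of a group of 7 heavy atoms (3 carbon, 1 nitrogen, 2 oxygen, 1 sulfur; one five-membered non-aromatic ring with 2 hetero atoms), on a saturated chain carbon bound to an aromatic carbon and a saturated chain carbon. Within the data shown here, no step between measured compounds isolates this change. Compound 2 already carries a double bond out to its heterocycle and sits in the same range as compound 1, so no step beyond the scatter is expected in either direction. Compound 3 is therefore expected to give about 25 nM in this assay, between 10 nM and 70 nM, which means an estimated step of no change at the digits printed from compound 1 to compound 3 (within the scatter).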

Compound 3, inhibition constant: 13 nM
Estimate against measurement, compound 3: 1.9-fold (0.28 log units) above; measured number inside the range.
By their numbers in this assay, from the lowest: compounds 3, 2 and 1 (each within the scatter of the next).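

In this assay, among these compounds, the group of 8 heavy atoms with 3 double bonds outside aromatic rings, in place of 2,4-dioxo-1,3-thiazolidin-5-yl on the saturated chain carbon, gives a 1.9-fold lower number from compound 1 to compound 3 (0.28 log units; within the scatter), the first step that isolates a change at this position. This position therefore accepts the larger group carrying the additional double bond, with no step beyond the scatter in this assay. No supporting evidence bears on this result.

Going by these compounds, whether a carboxylic acid or an amine in place of the five-membered ring would keep the number in this range remains open. The compounds shown also leave open how the other geometry of the new double bond would read at this position.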